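The source may report more compounds than this note shows. Statements on the series, on what has been measured and on what is new or still open speak of the compounds shown alone.

Measured so far in a functional assay on HUVEC cells (Homo sapiens) for inhibition, tested at 5 ug/mL; a lower number here means a weaker effect, a higher number a stronger effect of the compound at the concentration tested:

Compound 1 `COc1cc(/C=C/C(=O)c2cccc(NC(=O)c3ccc(Cl)cc3)c2)ccc1O`: 42%
Compound 2 `COc1cc(/C=C/C(=O)c2cccc(N)c2)ccc1O`: 50%
Compound 3 `COC(=O)C(=O)Nc1cccc(C(=O)/C=C/c2ccc(O)c(OC)c2)c1`: 20%

Compound 3 stands lowest of the three numbers in this assay; the steps that lead to it, a number 22 percentage points lower from compound 1 to compound 3 (beyond the scatter) and a number 30 percentage points lower from compound 2 to compound 3 (beyond the scatter), are both modest and lie beyond the scatter.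

Compound 4 `CCOC(=O)C(=O)Nc1cccc(C(=O)/C=C/c2ccc(O)c(OC)c2)c1` differs from compound 3 by methyl in place of hydrogen on a saturated chain carbon bound to an oxygen next to a carbonyl group. Within the data shown here, no measured step touches this place: the two steps above exchange the whole group on the aromatic nitrogen, not a single carbon on the saturated chain. With only that to go on, a step within the scatter is expected from compound 3 to compound 4, with no preferred direction, no change at the digits printed from compound 3 to compound 4 (within the scatter). Compound 4 is therefore estimated at 20% in this assay, in the range 5% to 38%.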

Compound 4, a percentage reported as inhibition, at one concentration (the size of the read-out at that concentration, not a potency): 45%
Compound 4: middle estimate off by 25 percentage points, on the low side; the measured number lies above the stated range.
By their numbers in this assay, from the lowest: compound 3; then compounds 1, 4 and 2 (each within the scatter of the next).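

In this assay this place on the saturated chain is not silent: methyl in place of hydrogen, which turns methoxycarbonyl into ethoxycarbonyl, gives (a number 25 percentage points higher from compound 3 to compound 4 (beyond the scatter)). A single added carbon therefore separates the two esters, and the ethoxycarbonyl compound sits level with the other two acylation states of the nitrogen (a number 5 percentage points lower from compound 2 to compound 4 (within the scatter)) and (a number 3 percentage points higher from compound 1 to compound 4 (within the scatter)). No measurement at hand explains the step. Open, going by these compounds, is whether a longer chain such as propyl, a branched isopropyl, or a carboxylic acid at this place holds the read-out of the ethyl ester.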